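Chloro for hydrogen on the core: a second instance

A few compounds are considered here, and "the series" means these few. Any claim that something is new, unique, unknown or untested is made for them only; others in the source may bear on it.

In a functional assay on SN12C cells (Homo sapiens) for cytotoxicity, read by sulforhodamine B assay, with a stated time of 48 h (on this read-out lower numbers stand for higher toxicity in this test and higher numbers for lower toxicity in this test), compound 1 `ClCc1ccccc1Cn1cnc2c(Cl)nc(Cl)nc21` gives 4670 nM, compound 2 `ClCc1ccccc1Cn1cnc2c(Cl)ncnc21` gives 95500 nM, and compound 3 `ClCc1cccc(Cn2cnc3c(Cl)ncnc32)c1` gives 14500 nM. The difference between the cores of compound 2 and compound 3 is not broken down here. Compound 1 differs from compound 2 by chloro in place of hydrogen on an aromatic carbon, a step of a 20-fold lower number from compound 2 to compound 1 (1.31 log units; beyond the scatter). Compound 4 `ClCc1cccc(Cn2cnc3c(Cl)nc(Cl)nc32)c1` is not yet measured in this assay; it differs from compound 3 by chloro in place of hydrogen on an aromatic carbon, the same change at the same place. The expectation rests on that single earlier step only. The step from compound 3 to compound 4 is expected to be a 9.7-fold lower number from compound 3 to compound 4 (0.99 log units; beyond the scatter), somewhat smaller than the earlier one because compound 3 at 14500 nM already stands well below compound 2. Compound 4 is expected near 1500 nM, between 400 nM and 6000 nM.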

Compound 4, concentration lethal to 50% of the cells: 11800 nM
Estimate against measurement, compound 4: 7.9-fold (0.90 log units) below, and the stated range ends below it.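

In this assay, chloro in place of hydrogen on an aromatic carbon gives a 1.2-fold lower number from compound 3 to compound 4 (0.09 log units; within the scatter), so the size of the earlier step does not carry over to this core: the same change on two cores in this assay, a 20-fold lower number (1.31 log units; beyond the scatter) from compound 2 to compound 1 and a 1.2-fold lower number (0.09 log units; within the scatter) from compound 3 to compound 4, 17-fold (1.22 log units) apart, beyond the scatter of two such steps

The change therefore cannot be transferred between these two cores at a fixed size, even with the same group entering at the same place. Going by these compounds alone, with only two pairs, this is no general rule for the series, and the data do not show which part of the difference between the cores goes with the gap between the steps.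

From the compounds shown here alone, it remains open how an amine or a methoxy group would behave at the same ring carbon on each core. Also open, going by these compounds, is whether a hydroxymethyl group in place of the chloromethyl group would leave the two steps as far apart.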